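Carbamoyl in place of the dienyl ether: outlook for compound 3

This account rests on a few compounds, and the source may have more. Where it says the series, first, only, none or still open, it means among the compounds named here.

Compound 1 `CC(C)=CCC/C(C)=C/COc1cc(=O)n(CCCO)c2c1CC(CC=C(C)C)C(C)(C)C2` gives 18.4% in a functional assay on PANC-1 cells (Homo sapiens) for inhibition, read by MTT assay, with a stated time of 24 h, tested at 10 uM (on this read-out lower numbers stand for less inhibition and higher numbers for more inhibition at the one concentration tested (going by the name of the read-out)), the higher of the two numbers recorded so far. Compound 2 `CC(C)=CCC1Cc2c(OCCCNS(=O)(=O)c3ccc(Cl)cc3)cc(=O)n(CCCO)c2CC1(C)C` gives 9.8% in this assay, a gap within the scatter, so the two are read as alike. Compound 3 `CC(C)=CCC1Cc2c(OC(=O)Nc3ccc(F)c(Cl)c3)cc(=O)n(CCCO)c2CC1(C)C` differs from compound 1 by (3-chloro-4-fluorophenyl)carbamoyl in place of 3,7-dimethylocta-2,6-dien-1-yl on an oxygen on an aromatic ring. Within the data shown here, no measured pair covers a change of this kind, so no direction can be inferred from the data. The expected step of a number 2.4 percentage points lower from compound 1 to compound 3 (within the scatter) is therefore taken as none beyond the scatter. Compound 3 is estimated at 16% in this assay, within a range from 3% to 36% that allows a shift either way.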

Compound 3, a percentage reported as inhibition, at one concentration (the size of the read-out at that concentration, not a potency): 0%
Beside the measured number, compound 3's estimate is 16 percentage points above it; the whole stated range lies above it.
By their numbers in this assay, from the lowest: compounds 3, 2 and 1 (each within the scatter of the next, the first and the last beyond it).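

In this assay, among these compounds, the replacement of 3,7-dimethylocta-2,6-dien-1-yl by (3-chloro-4-fluorophenyl)carbamoyl on an oxygen on an aromatic ring gives a number 18.4 percentage points lower from compound 1 to compound 3 (beyond the scatter) as the first step that can be read. The group on this oxygen therefore matters to the read-out, and this change does not preserve the inhibition seen with compound 1. No measurement bears on the reason for this step.

Still open, from the compounds shown here alone, is whether the carbamoyl link or the chlorinated and fluorinated ring carries the step. Going by these compounds, it is also open how an aminoalkyl chain or a carboxylic acid on this oxygen would compare with the dienyl chain.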